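The source may report more compounds than this note shows. Statements on the series, on what has been measured and on what is new or still open speak of the compounds shown alone.

Compound 3 `COc1cc(N)c(Cl)cc1NC(=O)C1CCN(Cc2ccc([N+](=O)[O-])cc2)CC1` stands only at a limit: in a functional assay on the whole organism for antagonist activity, with Mus musculus as the target (a higher number here means that more compound is needed for the effect, a lower number that less compound is needed), compound 3 gives > 4 mg/kg. Compound 1 `COc1ccc(CN2CCC(C(=O)Nc3cc(Cl)c(N)cc3OC)CC2)cc1` gives 0.9 mg/kg. Compound 2 `COc1cc(N)c(Cl)cc1NC(=O)C1CCN(CC2CCCCCC2)CC1` sits at a limit too, giving > 10 mg/kg. Compound 4 `COc1cc(N)c(Cl)cc1NC(=O)C1CCN(Cc2ccc(OCc3ccccc3)cc2)CC1` carries benzyloxy in place of nitro on an aromatic carbon. The measured step that bears on this is an at least 4.4-fold higher number from compound 1 to compound 3 (0.64 log units; beyond the scatter), where nitro replaced methoxy; since benzyloxy, like methoxy, is an alkoxy group, the change back from nitro is expected to lower the number, though the limit of compound 3 leaves the size uncertain. The step of an at least 11-fold higher number from compound 1 to compound 2 (1.04 log units; beyond the scatter) concerns the group on the amine nitrogen in the ring, which is unchanged here. Compound 4 is therefore expected to give 2 mg/kg (range 0.6 mg/kg to 8 mg/kg), a step of an at least 2.0-fold lower number from compound 3 to compound 4 (0.30 log units; that floor lies within the scatter).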

Compound 4, dose for half-maximal effect: > 4 mg/kg
Compound 4 ended at the assay's limit (the forecaster's own chance of this, stated with the estimate: 25%); middle value at least 2.0-fold (0.30 log units) from the limit.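

In this assay, putting a phenyl on the methoxy group of compound 1 gives an at least 4.4-fold higher number from compound 1 to compound 4 (0.64 log units; beyond the scatter). At this aromatic carbon, then, benzyloxy does not behave like methoxy, and neither benzyloxy nor nitro keeps the value of compound 1. The step between compound 3 and compound 4 cannot be read, as both values are limits: the limit of > 4 mg/kg in this assay, at which 2 of the 4 values shown sit. Still open, as far as these compounds go, is whether a small alkoxy group such as ethoxy, or an amine, on the same aromatic carbon would stay close to compound 1, which gives 0.9 mg/kg.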